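From benzyl to bromo: one swap, one open number

This account rests on a few compounds, and the source may have more. Where it says the series, first, only, none or still open, it means among the compounds named here.

Compound 1 `COc1ccc(O)c(C(=O)Nc2ccc(C#N)cc2)c1`: > 10000 nM (a limit, not a number)
Compound 2 `N#Cc1ccc(NC(=O)c2cc(Cc3ccccc3)ccc2O)cc1`: 1930 nM
Compound 3 `O=C(Nc1cccc(OC(F)(F)F)c1)c1cc(F)ccc1O`: 830 nM

These values come from a functional assay on KG-1 cells (Homo sapiens) for cytotoxicity, read by luminescence and CellTiter-Glo, with a stated time of 3 days; on this read-out higher numbers stand for weaker inhibition and lower numbers for stronger inhibition. Within the data shown here, only two compounds have actual numbers so far: compound 2 has the higher one and compound 3 the lower. The value of compound 1 is a limit of the assay.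

Compound 4 `N#Cc1ccc(NC(=O)c2cc(Br)ccc2O)cc1` is still unmeasured. The change from compound 2 is bromo in place of benzyl on an aromatic carbon, which puts bromo in place of benzyl on an aromatic carbon, para to a hydroxy group.

Among the measured compounds shown here, one measured step bears on this place: an at least 5.1-fold lower number from compound 1 to compound 2 (0.71 log units; beyond the scatter). For the measured compounds named here, it suggests that losing benzyl may carry a cost, but no measured compound tests bromo there. Compound 3, at 830 nM, has no benzyl yet still gives a number, although it differs from compound 2 in more than one place. A higher number is therefore the likelier direction in this assay, but only a small change is expected: a 1.6-fold higher number from compound 2 to compound 4 (0.19 log units; within the scatter). For compound 4, the estimated value is 3000 nM, with an expected range from 900 nM to 10000 nM.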

Compound 4, half-maximal inhibitory concentration: 1290 nM
For compound 4 the middle estimate is 2.3-fold (0.37 log units) above the measured one; measured number inside the range.
By their numbers in this assay, from the lowest: compounds 3, 4 and 2 (each within the scatter of the next, the first and the last beyond it). At a limit, above all of these: compound 1.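

In this assay, putting bromo in place of benzyl, para to a hydroxy group, gives a 1.5-fold lower number from compound 2 to compound 4 (0.17 log units; within the scatter), so at this position the six-membered aromatic ring of benzyl is not needed for a measurable number. Putting bromo in place of methoxy at the same position gives an at least 7.7-fold lower number from compound 1 to compound 4 (0.88 log units; beyond the scatter), so a second, much smaller group now also gives a number where methoxy does not. Compound 1 stands at a limit and not at a number: the limit of > 10000 nM in this assay, at which 1 of the 4 values shown sits.

From the compounds shown here alone, the full size of the step away from methoxy stays unknown, and so does whether anything about the group beyond its not being methoxy matters. Going by these compounds, whether chloro, an amine or a carboxylic acid at this position would also give a number in this assay remains open.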